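Methoxy to Methylsulfanyl on a Selenium-Bearing Core

The compounds below may be only part of what the source reports. "The series", "measured", "known", "first", "only" and "open" are said of these compounds alone.

Of the compounds shown here, three have been tested in a functional assay on HT-29 cells (Homo sapiens) for cytotoxicity, read by MTT assay, with a stated time of 72 h; on this read-out higher numbers stand for weaker inhibition of growth and lower numbers for stronger inhibition of growth. Compound 1 `C[Se]c1nc(N)c2ccccc2n1` gives 74800 nM. Compound 2 `CCCCC[Se]c1nc([Se]CCCCC)c2cccnc2n1` reaches only a limit of the assay, > 100000 nM. Compound 3 `COc1ccc(CNc2nc([SeH])nc3ccccc23)cc1` likewise reaches only a limit of the assay, > 100000 nM. So for compound 3 no number is known at all, only a limit, and it stands at that limit together with one other compound (the limit of > 100000 nM in this assay, at which 2 of the 3 values shown sit). Compound 1 is the only one of the three with an actual number.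

Compound 4 `CSc1ccc(CNc2nc([SeH])nc3ccccc23)cc1` differs from compound 3 in one place: methylsulfanyl in place of methoxy on an aromatic carbon. Among the compounds with values here, no measured pair in this set shows what such a swap does in this assay, and compound 3 itself offers only a limit as a starting point. Within the data shown here, with no measured step to lean on, the expectation is a step of a number no higher from compound 3 to compound 4 (the limit leaves the size open), which is none beyond the usual scatter. Compound 4 is therefore expected to sit near the same limit, estimated at 100000 nM with a range from 30000 nM to 300000 nM, and it is likely that this assay again reports only a limit for compound 4.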

Compound 4, concentration for total growth inhibition: > 100000 nM
Compound 4 ended at the assay's limit; the forecaster's own chance of this, stated with the estimate: 70%; the middle value sits exactly at the limit.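

Compound 3 and compound 4 both give only a limit in this assay, not a number, so no step can be read for the swap from methoxy to methylsulfanyl: the limit of > 100000 nM in this assay, at which 3 of the 4 values shown sit.

The compounds shown leave open whether this swap changes growth inhibition at all, and what actual numbers compound 3 and compound 4 would have.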